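From Compound 1 to Compound 4: One Added Carbonyl

The source may hold more compounds than are shown below. What is called first, only, known or untested is meant among the compounds shown, and "the series" means these compounds.

Compound 1 `O=C(NNc1ccccc1Cl)c1cccc(NS(=O)(=O)c2cnc(O)nc2O)c1` - 3350 nM
Compound 2 `Cc1ccccc1NNC(=O)c1ccccc1NS(=O)(=O)c1cnc(O)nc1O` - a limit of the assay, not a number - > 20000 nM
Compound 3 `CCCCOc1ccc(C(=O)NNC(=O)c2ccc(NS(=O)(=O)c3cnc(O)nc3O)cc2)cc1` - 12800 nM

These values come from a functional assay on OVCAR-3 cells (Homo sapiens) for antiproliferative activity, read by MTT assay, with a stated time of 24 h (a higher number here means a weaker inhibitor, a lower number a stronger inhibitor), and show how strongly each compound holds back cell growth. Compound 1 has the lowest of the two actual numbers, and the gap up to compound 3 lies beyond the scatter.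

Compound 4 `O=C(NNC(=O)c1ccccc1Cl)c1cccc(NS(=O)(=O)c2cnc(O)nc2O)c1` has (2-chlorophenyl)carbonyl in place of 2-chlorophenyl on an amine nitrogen and has not yet been tested. Within the data shown here, no measured pair shows this change alone, so any forecast rests on thin evidence. Compound 1 already sits at the low end, and the other number belongs to compound 3 (12800 nM), so a modest upward step in this assay seems more likely than a downward one. The expected change is a 2.1-fold higher number from compound 1 to compound 4 (0.32 log units; beyond the scatter) and points to a somewhat weaker inhibitor.

For compound 4 the estimated value is 7000 nM (expected range 2500 nM to 20000 nM).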

Compound 4, half-maximal inhibitory concentration: 7300 nM
Beside the measured number, compound 4's estimate is 1.0-fold (0.02 log units) below it; measured number inside the range.
By their numbers in this assay, from the lowest: compound 1; then compounds 4 and 3 (each within the scatter of the next). At a limit, above all of these: compound 2.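

Among these compounds, compound 4 gives the first direct reading of this position: in this assay, (2-chlorophenyl)carbonyl in place of 2-chlorophenyl on an amine nitrogen gives a 2.2-fold higher number from compound 1 to compound 4 (0.34 log units; beyond the scatter). Among the compounds shown here, the earlier compounds differ from one another in more than one place, so none of them could isolate this change, whereas here the added carbonyl is the only difference and the step, though modest, lies beyond the usual scatter. Nothing measured here explains the step.

From the compounds shown here alone, it remains open whether the carbonyl alone accounts for this step or whether the ring attached to it also contributes, and a small acetyl group on the same nitrogen would separate those two readings. Going by these compounds, the role of the chlorine also remains open, as would be tested by an unsubstituted benzoyl group.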